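One Chloro Fewer: Expecting the Cytotoxicity of Compound 3

The source may hold more compounds than are shown below. What is called first, only, known or untested is meant among the compounds shown, and "the series" means these compounds.

Two measured compounds share a core and differ in one aryl group. Compound 1 `O=C1/C(=C\c2c(Cl)cccc2Cl)c2ccccc2N1c1c(Cl)cccc1Cl` was tested in a functional assay on KB cells (Homo sapiens) for cytotoxicity, read by MTT assay, with a stated time of 72 h (a higher number here means that more compound is needed for the effect, a lower number that less compound is needed), where compound 1 gives 50 ug/mL. Going by the values given here, compound 2 `CN(C)c1ccc(/C=C2\C(=O)N(c3c(Cl)cccc3Cl)c3ccccc32)cc1` gives 15 ug/mL, and the step of a 3.3-fold lower number from compound 1 to compound 2 (0.52 log units; beyond the scatter) is the only measured step so far, so compound 1 stands with the higher number of the two. Compound 3 `O=C1/C(=C\c2ccccc2Cl)c2ccccc2N1c1c(Cl)cccc1Cl` has not been measured; it differs from compound 1 by hydrogen in place of chloro on an aromatic carbon. Among the compounds with values here, the one measured step exchanged the whole aryl group and moved the number only modestly; removing a single chloro inside that same group is a smaller change, and no measured step shows how it acts. The change from compound 1 to compound 3 is therefore expected to remain within the scatter, as a 1.3-fold lower number from compound 1 to compound 3 (0.10 log units; within the scatter). For compound 3 the estimate is 40 ug/mL, with a range from 15 ug/mL to 100 ug/mL.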

Compound 3, concentration for half-maximal effect: 5 ug/mL
Compound 3: middle estimate off by 8.0-fold (0.90 log units), on the high side; measured number below the stated range.
By their numbers in this assay, from the lowest: compound 3; then compound 2; then compound 1.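

In this assay, going by these compounds alone, this aromatic carbon proves far more sensitive than the earlier compounds could show: hydrogen in place of chloro gives a 10-fold lower number from compound 1 to compound 3 (1.00 log units; beyond the scatter) and thus turns the compound with the highest number into the one with the lowest. The change from 2,6-dichlorophenyl to 2-chlorophenyl also takes the series past the 4-(dimethylamino)phenyl compound, with a 3.0-fold lower number from compound 2 to compound 3 (0.48 log units; beyond the scatter) as the step between those two aryl groups, so a 2-chlorophenyl group does better here than either aryl group seen before. Nothing available explains why losing one chloro has this effect.

The compounds shown leave open what a plain phenyl group, with the second chloro gone as well, would give in this assay on this carbon. They also leave open whether a fluoro or a methoxy group at that place would behave more like hydrogen or like chloro.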